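From iodo to chloro in a growth inhibitor

This account rests on a few compounds, and the source may have more. Where it says the series, first, only, none or still open, it means among the compounds named here.

Among the compounds with values here, in a functional assay on OVCAR-5 cells (Homo sapiens) for inhibition (a lower number here means a stronger inhibitor of growth, a higher number a weaker inhibitor of growth), compound 1 (`Nc1ccc(-c2nc3ccc(F)cc3s2)cc1I`) gives 100 nM and holds the lower of the two numbers known so far, while compound 2 (`Cc1cc(-c2nc3c(F)cccc3s2)ccc1N`) gives 1700 nM and lies beyond the scatter from it. Compound 3 (`Nc1ccc(-c2nc3ccc(F)cc3s2)cc1Cl`) carries chloro in place of iodo on an aromatic carbon, ortho to an amino group (chloro in place of iodo on an aromatic carbon). Within the data shown here, no measured pair shows this change, so the data offer no direct guide. A small step within the scatter, with no firm direction, is expected (a 1.2-fold higher number from compound 1 to compound 3 (0.08 log units; within the scatter)). In this assay compound 3 is estimated at 120 nM (range 30 nM to 500 nM).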

Compound 3, concentration for 50% growth inhibition: 70 nM
Compound 3: middle estimate off by 1.7-fold (0.23 log units), on the high side; measured number inside the range.
By their numbers in this assay, from the lowest: compounds 3 and 1 (each within the scatter of the next); then compound 2.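

Within the data shown here, with a 1.4-fold lower number from compound 1 to compound 3 (0.15 log units; within the scatter), chloro in place of iodo gives the first direct reading at this position on an aromatic carbon, ortho to an amino group. In this assay, compound 1 and compound 3 stay within the scatter of each other, so on the shared core this exchange of one halogen for another leaves growth inhibition unresolved from its starting level. No outside measurement bears on this result. The compounds shown leave open whether a methoxy group or a carboxylic acid on the same carbon would hold that level. They also leave open what removing the halogen altogether would do.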